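Oxadiazole to Oxazole on a Shared Core

The source may report more compounds than this note shows. Statements on the series, on what has been measured and on what is new or still open speak of the compounds shown alone.

Going by the values given here, in a functional assay on HCT-116 cells (Homo sapiens) for inhibition, read by MTT assay, with a stated time of 48 h, tested at 2 uM (a higher number here means more inhibition at the concentration tested (going by the name of the read-out), a lower number less inhibition), compound 2 `Cc1noc(C)c1-c1ccc2c(c1)C(c1ccccc1)N(Cc1nnc(-c3ccccc3)o1)C(=O)N2C` gives 31.4%, and compound 1 `Cc1noc(C)c1-c1ccc2c(c1)C(c1ccccc1)NC(=O)N2C` gives 27.8%, so the two numbers measured so far sit within the scatter of each other. Compound 3 `Cc1noc(C)c1-c1ccc2c(c1)C(c1ccccc1)N(Cc1ncc(-c3ccccc3)o1)C(=O)N2C` differs from compound 2 by 5-phenyl-1,3-oxazol-2-yl in place of 5-phenyl-1,3,4-oxadiazol-2-yl on a saturated chain carbon bound to an amide-type nitrogen in a ring. Among the compounds with values here, the one measured step, a number 3.6 percentage points higher from compound 1 to compound 2 (within the scatter), concerns attaching the whole side group, not altering its ring, and lies within the scatter. Nothing measured bears directly on this change, so the expected step of a number 1.4 percentage points lower from compound 2 to compound 3 (within the scatter) stays within the scatter. Compound 3 is therefore estimated to give 30%, in a range of 15% to 45%.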

Compound 3, a percentage reported as inhibition, at one concentration (the size of the read-out at that concentration, not a potency): 30%
Compound 3: the middle estimate sits on the measured number at the digits printed; measured number inside the range.
By their numbers in this assay, from the lowest: compounds 1, 3 and 2 (each within the scatter of the next).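

In this assay, the ring change itself gives a number 1.4 percentage points lower from compound 2 to compound 3 (within the scatter), so 5-phenyl-1,3-oxazol-2-yl and 5-phenyl-1,3,4-oxadiazol-2-yl cannot be told apart at this position. Placing (5-phenyl-1,3-oxazol-2-yl)methyl in place of hydrogen on the amide-type nitrogen gives a number 2.2 percentage points higher from compound 1 to compound 3 (within the scatter), so neither side group shown separates from the unsubstituted compound. No supporting data offer an explanation for these results. Still open, on these data alone, is whether a longer chain in place of the methyl link, or an amine on the outer phenyl ring, would move the number beyond the scatter.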